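Working notes: swapping bromo for phenyl

The source may hold more compounds than are shown below. What is called first, only, known or untested is meant among the compounds shown, and "the series" means these compounds.

Values in a functional assay on KYSE-410 cells (Homo sapiens) for antiproliferative activity, read by MTT assay, with a stated time of 72 h (on this read-out higher numbers stand for weaker inhibition and lower numbers for stronger inhibition), for the series so far:
- Compound 1 `O=C(Nc1ccc(Cl)cc1)c1cc(=O)[nH]c2cc(Br)ccc12` gives > 20000 nM (a limit, not a number)
- Compound 2 `O=C(Nc1ccc(F)cc1)c1cc(=O)[nH]c2cc(Br)ccc12` gives > 20000 nM (a limit, not a number)
- Compound 3 `O=C(Nc1cccc(F)c1)c1cc(=O)[nH]c2cc(Br)ccc12` gives 7300 nM

Going by the values given here, compound 3 holds the only true number here, and the other two values sit at the limit of > 20000 nM in this assay, at which 2 of the 3 values shown sit, in the notes. Compound 4 `O=C(Nc1cccc(F)c1)c1cc(=O)[nH]c2cc(-c3ccccc3)ccc12` differs from compound 3 by phenyl in place of bromo on an aromatic carbon. The measured steps, an at least 2.7-fold lower number from compound 1 to compound 3 (0.43 log units; beyond the scatter) and an at least 2.7-fold lower number from compound 2 to compound 3 (0.43 log units; beyond the scatter), both change the group on the amide-type nitrogen. Neither touches the bromo, so they give no size for this change, and no step beyond the scatter is expected in this assay with any confidence. The expected step is a 1.2-fold lower number from compound 3 to compound 4 (0.09 log units; within the scatter) in this wide estimate. The expected value for compound 4 is 6000 nM with an estimated range from 1500 nM to 20000 nM in this series.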

Compound 4, half-maximal inhibitory concentration: > 20000 nM
Compound 4 was reported as a limit; the forecaster's own chance of this, stated with the estimate: 30%; middle value at least 3.3-fold (0.52 log units) away from the limit.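

In this assay, going by these compounds alone, phenyl in place of bromo on an aromatic carbon gives an at least 2.7-fold higher number from compound 3 to compound 4 (0.43 log units; beyond the scatter) and so provides the first measured change at this position of the shared core. With the 3-fluorophenyl group on the amide-type nitrogen held fixed, bromo is the better of the two groups here. Compound 4 is reported only as a limit, so the step has a floor and no readable upper size: the limit of > 20000 nM in this assay, at which 3 of the 4 values shown sit.

On these data alone, whether a methoxy group or an amine at this position would give a readable number stays open. Also open, as far as these compounds go, is whether the step holds with other groups on the amide-type nitrogen.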